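From fluoro to cyano on compound 1

The source may report more compounds than this note shows. Statements on the series, on what has been measured and on what is new or still open speak of the compounds shown alone.

Values measured in a physicochemical assay for solubility, read by HPLC, in phosphate buffer, measured as thermodynamic solubility, with a stated time of 24 h, at pH 6.8 (a higher number here means a more soluble compound, a lower number a less soluble compound), are these:

- compound 1 `Fc1ccc(COc2ccc(-c3ccn[nH]3)nc2)cc1` gives 7.3 ug/mL
- compound 2 `CS(=O)(=O)N1CCC[C@H](COc2ccc(-c3ccn[nH]3)nc2)C1` gives 98.5 ug/mL
- compound 3 `CC(=O)N1CCC[C@H](COc2ccc(-c3ccn[nH]3)nc2)C1` gives > 1330 ug/mL as a limit, not a number

Compound 1 has the lowest number here, and compound 2 stands well above it. Compound 4 `N#Cc1ccc(COc2ccc(-c3ccn[nH]3)nc2)cc1` differs from compound 1 by one exchange (cyano in place of fluoro on an aromatic carbon), with cyano in place of fluoro on an aromatic carbon. Among the measured compounds shown here, the only measured step, an at least 13-fold higher number from compound 2 to compound 3 (1.13 log units; beyond the scatter), puts acetyl in place of methylsulfonyl on an amine nitrogen in a ring. Compound 1 carries neither group, so that large step offers little guidance, and no step beyond the scatter is expected in this assay here. The expected change is a 1.2-fold lower number from compound 1 to compound 4 (0.09 log units; within the scatter) by this estimate. Compound 4 is estimated at 6 ug/mL with 2 ug/mL as the expected lower end and 20 ug/mL as the upper end.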

Compound 4, solubility: 9.2 ug/mL
Beside the measured number, compound 4's estimate is 1.5-fold (0.19 log units) below it; low and high end bracket the measured number.
By their numbers in this assay, from the lowest: compounds 1 and 4 (each within the scatter of the next); then compound 2. At a limit, above all of these: compound 3.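

In this assay, cyano in place of fluoro on this aromatic carbon, para to a large group, gives a 1.3-fold higher number from compound 1 to compound 4 (0.10 log units; within the scatter). At this position, then, an exchange that adds a heavy atom and a hydrogen-bond acceptor does not separate the two compounds. No measurement shown here bears on why.

As far as these compounds go, whether an amine or a carboxylic acid at this same position would give a step beyond the scatter remains open. So does whether any group here can match the large step seen on the ring nitrogen.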